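Swapping Chlorine for Fluorine on a Weaker Analogue

A few compounds are considered here, and "the series" means these few. Any claim that something is new, unique, unknown or untested is made for them only; others in the source may bear on it.

Compound 3 `N#Cc1c(NCc2ccccc2)c(Cl)c2nc(N)nc(N)c2c1NCc1ccccc1` gives 19.2 ug/mL in a functional assay on HepG2 cells (Homo sapiens) for cytotoxicity, read by MTT assay (a lower number here means a stronger inhibitor, a higher number a weaker inhibitor), the second highest of the three numbers measured; compound 2 `N#Cc1c(NCc2ccccc2)c(F)c2nc(N)nc(N)c2c1F` gives 27.8 ug/mL, within the scatter of compound 3, while compound 1 `N#Cc1c(NCc2ccccc2)c(Cl)c2nc(N)nc(N)c2c1F` gives 1.4 ug/mL, a 14-fold higher number from compound 1 to compound 3 (1.14 log units; beyond the scatter). Compound 4 `N#Cc1c(NCc2ccccc2)c(F)c2nc(N)nc(N)c2c1NCc1ccccc1` differs from compound 3 by fluoro in place of chloro on an aromatic carbon. The same exchange has been measured once already: a 20-fold higher number from compound 1 to compound 2 (1.30 log units; beyond the scatter). As far as these compounds go, that step bears directly on the present one, so a large rise in the number is expected for compound 4, though how fully the effect carries over to an analogue that already shows a higher number is unknown. Compound 4 is therefore estimated at 120 ug/mL, with a range from 40 ug/mL to 400 ug/mL. This amounts to an expected 6.3-fold higher number from compound 3 to compound 4 (0.80 log units; beyond the scatter).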

Compound 4, half-maximal inhibitory concentration: 13.4 ug/mL
Estimate against measurement, compound 4: 9.0-fold (0.95 log units) above; measured number outside the range, below it.
By their numbers in this assay, from the lowest: compound 1; then compounds 4, 3 and 2 (each within the scatter of the next, the first and the last beyond it).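

The exchange of chloro for fluoro at this position has no fixed size across the two cores: the same change on two cores in this assay, a 20-fold higher number (1.30 log units; beyond the scatter) from compound 1 to compound 2 and a 1.4-fold lower number (0.16 log units; within the scatter) from compound 3 to compound 4, 28-fold (1.45 log units) apart, beyond the scatter of two such steps. With a benzylamino group para to this position, it gives a 1.4-fold lower number from compound 3 to compound 4 (0.16 log units; within the scatter), so the large step between compound 1 and compound 2 does not carry over. Benzylamino in place of fluoro likewise depends on the group at this position, giving a 2.1-fold lower number from compound 2 to compound 4 (0.32 log units; beyond the scatter): the same change on two cores in this assay, a 14-fold higher number (1.14 log units; beyond the scatter) from compound 1 to compound 3 and a 2.1-fold lower number (0.32 log units; beyond the scatter) from compound 2 to compound 4, 28-fold (1.45 log units) apart, beyond the scatter of two such steps.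

The compounds shown leave open whether bromo or methyl at this position, or a simple amino group in place of benzylamino, would follow compound 1 or compound 4.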